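Homologation at the cyanoguanidine terminus in a pyridazinone series

A few compounds are considered here, and "the series" means these few. Any claim that something is new, unique, unknown or untested is made for them only; others in the source may bear on it.

Measured so far in a functional assay on the whole organism (stomach) with Rattus norvegicus as the target; a lower number here means that less compound is needed, a higher number that more compound is needed for the effect:
compound 1, `C/N=C(/NC#N)NCCCCCCn1nc(-c2ccccc2)ccc1=O`: > 100 mg/kg
compound 2, `CC/N=C(/NC#N)NCCCCCn1nc(-c2ccccc2)ccc1=O`: 100 mg/kg

The two measured compounds share the same core and differ only in the group on the saturated chain carbon five bonds along the chain from an aromatic nitrogen. For compound 1 the value in this assay is a limit of the assay and not a number: > 100 mg/kg. For the measured compounds named here, compound 2 gives 100 mg/kg in this assay and is therefore the only compound with a number rather than a limit. The step of a number no higher from compound 1 to compound 2 (the limit leaves the size open) is a step whose size cannot be read because of the limit of > 100 mg/kg in this assay, at which 1 of the 2 values shown sits.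

Compound 3, `CCC/N=C(/NC#N)NCCCCCn1nc(-c2ccccc2)ccc1=O`, is the next member. Its difference from compound 2 is methyl in place of hydrogen on a saturated chain carbon, two bonds along the chain from a double-bonded nitrogen. Cut one bond further out, the same difference reads methyl to ethyl, ethyl to propyl. Going by the values given here, the only measured step does not report a size, so no measured step bears on this change with a readable magnitude. The change is expected to stay within the scatter, so the step is expected to be no change at the digits printed from compound 2 to compound 3 (within the scatter). Compound 3 is estimated at 100 mg/kg in this assay, within 40 mg/kg to 250 mg/kg.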

Compound 3, dose for half-maximal effect: > 100 mg/kg
Compound 3: a limit, no number; the forecaster's own chance of this, stated with the estimate: 45%; the middle value sits exactly at the limit.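

In this assay, methyl in place of hydrogen on a saturated chain carbon, two bonds along the chain from a double-bonded nitrogen, gives a number no lower from compound 2 to compound 3 (the limit leaves the size open). Compound 3 gives > 100 mg/kg, which is a limit of the assay and not a number. This first change at this position, read as ethyl to propyl, therefore brings no gain over compound 2, which remains the only compound with a number, while none of the steps around compound 3 has a readable size because of the assay limit: the limit of > 100 mg/kg in this assay, at which 2 of the 3 values shown sit.

Going by these compounds, how far compound 3 lies past its limit remains open, so the effect of this methyl cannot be sized, and the same holds for the comparison with compound 1. Also open, on these data alone, is whether a methyl group, a cyclopropyl group or a hydroxyethyl group in place of the propyl group, on the chain of compound 3, would give a number in this assay.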